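Acetyl to hydroxymethyl: the next step in the series

The source may hold more compounds than are shown below. What is called first, only, known or untested is meant among the compounds shown, and "the series" means these compounds.

Measured so far:
compound 1, `Fc1ccc(C2(c3ccc(F)cc3)CNC(c3cccc(C(F)(F)F)c3)=N2)cc1`, in an assay on LM cells for displacement of a labelled ligand from Neuropeptide Y receptor type 5 (Homo sapiens); a lower number here means a stronger inhibitor, a higher number a weaker inhibitor: 6.2 nM
compound 2, `CC(=O)c1cccc(C2=NC(c3ccc(F)cc3)(c3ccc(F)cc3)CN2)c1`, in this assay: 44 nM

Among the measured compounds shown here, compound 2 holds the highest of the two numbers in this assay; the nearest value is that of compound 1, and the one measured step, a 7.1-fold higher number from compound 1 to compound 2 (0.85 log units; beyond the scatter), separates them. Compound 3, `OCc1cccc(C2=NC(c3ccc(F)cc3)(c3ccc(F)cc3)CN2)c1`, differs from compound 2 by hydroxymethyl in place of acetyl on an aromatic carbon. For the measured compounds named here, no measured step carries a hydroxymethyl, so the only step that bears on this change is the one from trifluoromethyl to acetyl, of modest size, which shows the group at this position does move the number in this assay. With nothing measured for the new group, the expected step from compound 2 to compound 3 in this assay is a small one, a 1.5-fold higher number from compound 2 to compound 3 (0.17 log units; within the scatter), towards a somewhat higher number. Compound 3 is therefore estimated at 65 nM, with a range from 20 nM to 220 nM.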

Compound 3, half-maximal inhibitory concentration: 59 nM
Beside the measured number, compound 3's estimate is 1.1-fold (0.04 log units) above it; the measured number falls inside the stated range.
By their numbers in this assay, from the lowest: compound 1; then compounds 2 and 3 (each within the scatter of the next).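

In this assay the exchange of acetyl for hydroxymethyl gives a 1.3-fold higher number from compound 2 to compound 3 (0.13 log units; within the scatter) and so cannot be told apart from no change, even though the entering group carries a hydrogen-bond donor and lacks the double bond of the leaving one. Trifluoromethyl remains set apart from both groups: a 9.5-fold higher number from compound 1 to compound 3 (0.98 log units; beyond the scatter) is beyond the scatter, as is a 7.1-fold higher number from compound 1 to compound 2 (0.85 log units; beyond the scatter) for the acetyl compound, so in these three compounds the two oxygen-bearing groups read alike and only trifluoromethyl gives a lower number. Nothing measured here accounts for this pattern or links it to any property of the groups.

From the compounds shown here alone, whether an amine, a carboxylic acid or a longer chain at this position would stay with compound 2 and compound 3 or move towards compound 1 remains open. A methoxymethyl group, which would cap the hydroxyl hydrogen, would test whether the donor counts for anything in this series.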